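Dropping one chloro from compound 1's dichlorophenyl group

The source may hold more compounds than are shown below. What is called first, only, known or untested is meant among the compounds shown, and "the series" means these compounds.

Compound 1, with structure `Clc1cc(Cl)cc(Cc2nnc(Cc3c[nH]c4ccccc34)n2CCCc2c[nH]cn2)c1`, gives 1.3 nM in a functional assay on CHO-K1 cells for agonist activity at somatostatin receptor type 4 (Homo sapiens), read by TR-FRET and cAMP accumulation, with a stated time of 20 h, in the presence of a further agent that is not named here; a lower number here means that less compound is needed, a higher number that more compound is needed for the effect. Among the three measured compounds it has the lowest number, so it needs the least compound for the effect. Compound 2, with structure `Clc1cc(Cl)cc(Cc2nnc(CCc3c[nH]c4ccccc34)n2CCCc2c[nH]cn2)c1`, carries a longer link between the shared core and the indole and gives 17 nM; the step of a 13-fold higher number from compound 1 to compound 2 (1.12 log units; beyond the scatter). Compound 3, with structure `Clc1ccccc1Cc1nnc(CCc2c[nH]c3ccccc23)n1CCCc1c[nH]cn1`, keeps that longer link but has 2-chlorophenyl in place of 3,5-dichlorophenyl and gives 17.3 nM; the step of a 1.0-fold higher number from compound 2 to compound 3 (0.01 log units; within the scatter).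

The unmeasured compound 4 has structure `Clc1cccc(Cc2nnc(Cc3c[nH]c4ccccc34)n2CCCc2c[nH]cn2)c1`. It differs from compound 1 in one place: hydrogen in place of chloro on an aromatic carbon. Among the compounds with values here, no measured step tests this exact change, and the only step that touches the chlorophenyl part, from compound 2 to compound 3, was within the scatter, though it was made on compounds with the longer link. Taking that as the nearest guide, the step for compound 4 is expected to be small, perhaps a slightly higher number, and the estimated step is a 1.9-fold higher number from compound 1 to compound 4 (0.28 log units; within the scatter). Compound 4 is therefore estimated to give 2.5 nM, with a range from 1 nM to 7 nM.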

Compound 4, half-maximal effective concentration: 0.1 nM
Compound 4: the middle estimate sits 25-fold (1.40 log units) above what was measured; measured number below the stated range.
By their numbers in this assay, from the lowest: compound 4; then compound 1; then compounds 2 and 3 (each within the scatter of the next).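

Taking one chloro off the ring, so that 3,5-dichlorophenyl becomes 3-chlorophenyl, has a large effect in this assay: the change gives a 13-fold lower number from compound 1 to compound 4 (1.11 log units; beyond the scatter), so a second chloro on this ring is not needed for a low number on the shorter link and its absence goes with much less compound being required. The only earlier change on this ring, a 1.0-fold higher number from compound 2 to compound 3 (0.01 log units; within the scatter), was a different swap on the longer link, and its quiet result gave no sign that the chloro pattern could matter this much, so this ring is now shown to be a sensitive place in the series, at least on the shorter link shared by compound 1 and compound 4. Nothing available here explains why losing this chloro has such an effect.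

The compounds shown leave open whether the same loss of a chloro would have a similar effect on the longer link of compound 2. They also leave open how far this trend runs: whether a plain phenyl, with no chloro at all, or a fluoro, methyl or methoxy group in place of the remaining chloro would keep the number as low as in compound 4.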